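This account rests on a few compounds, and the source may have more. Where it says the series, first, only, none or still open, it means among the compounds named here.

In a functional assay on HL-60 cells (Homo sapiens) for inhibition, read by MTT assay, with a stated time of 72 h (a lower number here means a stronger inhibitor, a higher number a weaker inhibitor), compound 1 `Cc1nc(-c2ccc(F)cc2)c(C(=O)N2CCN(c3ccc(C(=O)C(C)C)cc3)CC2)o1` is reported as "not active" (no number reported), so it has no single number to stand on. Compound 2 `Cc1ccc(C)c(N2CCN(C(=O)c3oc(C)nc3-c3ccccc3F)CC2)c1`, which carries no isopropylcarbonyl, gives 319 nM in this assay. The move to compound 3 `Cc1nc(-c2ccc(F)cc2)c(C(=O)N2CCN(c3ccc(Cl)cc3)CC2)o1` puts chloro in place of isopropylcarbonyl on an aromatic carbon, para to a large group: chloro in place of isopropylcarbonyl on an aromatic carbon. For the measured compounds named here, no measured step between closely matched compounds is available to size this change, and compound 1 offers no number to count from. The expected direction in this assay is still toward stronger inhibition, from no reported activity to a measurable value, although a second inactive result remains possible. That expectation rests on compound 2 reaching 319 nM without the isopropylcarbonyl. For compound 3, the estimated value is 1000 nM, with an expected range of 200 nM to 5000 nM.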

Compound 3, half-maximal inhibitory concentration: "not active" (no number reported)
Compound 3: no number reported, so the estimate cannot be set against anything.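

Compound 1 and compound 3 both come without a number in this assay, so no step can be read between them. The compounds shown leave open whether chloro and isopropylcarbonyl differ at all in their effect. No supporting evidence bears on this result.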